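This account rests on a few compounds, and the source may have more. Where it says the series, first, only, none or still open, it means among the compounds named here.

Measured compounds:
compound 1 `N[C@H]1CC[C@H](Nc2c(C(=O)NCc3ccc(Cl)cc3Cl)nc(Br)c3cccnc23)CC1` - 6000 nM
compound 2 `CN(C)c1ccc(CNC(=O)c2nc(Br)c3cccnc3c2N[C@H]2CC[C@H](N)CC2)cc1` - "not determined" (no result reported)
compound 3 `N[C@H]1CC[C@H](Nc2c(C(=O)NCc3cccc(C(F)(F)F)c3)nc(Br)c3cccnc23)CC1` - "not determined" (no result reported)

The series shares one core and varies the group on the amide nitrogen. Among the measured compounds shown here, in a functional assay on HCT-116 cells (Homo sapiens) for cytotoxicity, read by MTT assay, with a stated time of 72 h (a lower number here means a stronger inhibitor, a higher number a weaker inhibitor), compound 1 gives 6000 nM, and this is the only number the series has so far. Compound 3 has no single number to stand on: its entry reads "not determined" (no result reported). Compound 2 is in the same position, with the entry "not determined" (no result reported). For the measured compounds named here, compound 3 therefore cannot be ranked against compound 1, and no measured step exists to serve as a guide.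

The next compound is compound 4 `N[C@H]1CC[C@H](Nc2c(C(=O)Nc3ccccc3)nc(Br)c3cccnc23)CC1`, which changes compound 3 at a single place: phenyl in place of 3-(trifluoromethyl)benzyl on an amide-type nitrogen. With no number for compound 3, the size of this step in this assay can only be expected, not derived. A modest step towards weaker inhibition is expected, not far beyond the usual scatter, though the data do not fix it. Going by the values given here, the only anchor is compound 1 at 6000 nM, so the expectation stays broad. For compound 4 the estimated value is 10000 nM, with an expected range from 3000 nM to 30000 nM.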

Compound 4, half-maximal inhibitory concentration: 2000 nM
Compound 4: middle estimate off by 5.0-fold (0.70 log units), on the high side; the measured number lies below the stated range.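

In this assay, the group on the amide nitrogen proves able to shift the read-out: phenyl in place of 2,4-dichlorobenzyl gives a 3.0-fold lower number from compound 1 to compound 4 (0.48 log units; beyond the scatter) and this modest step lies beyond the usual scatter, towards stronger inhibition. Among the compounds shown here, this is the first measured change at this position, and it shows that a phenyl attached directly to the amide nitrogen is compatible with activity in the cells, with the lower number of the pair going to the smaller group. Nothing available accounts for the direction or size of this step.

Compound 3 has no number, and its step to compound 4 cannot be read, which leaves the 3-(trifluoromethyl)benzyl group unplaced relative to both phenyl and 2,4-dichlorobenzyl. The compounds shown also leave open whether the difference between compound 1 and compound 4 follows the chlorines or the benzyl carbon, and how a phenyl carrying a single chlorine, an amine or a carboxylic acid, or a longer chain such as 2-phenylethyl, would read at this nitrogen.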